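Trading the Alkyne Chain for a Cyclohexyl Ring

The source may hold more compounds than are shown below. What is called first, only, known or untested is meant among the compounds shown, and "the series" means these compounds.

The three measured compounds share one core, carried by compound 1 `CCCCCCC#Cc1ccc(S(=O)(=O)Nc2cccc(-c3csc(NC(C)=O)n3)c2)cc1`, compound 2 `CC(=O)Nc1nc(-c2cccc(NS(=O)(=O)c3ccc(Br)cc3)c2)cs1` and compound 3 `CCCCC#Cc1ccc(S(=O)(=O)Nc2cccc(-c3csc(NC(C)=O)n3)c2)cc1`. In a functional assay on A-375 cells (Homo sapiens) for antiproliferative activity, read by trypan blue exclusion, with a stated time of 48 h, tested at 10 uM (on this read-out lower numbers stand for a stronger effect and higher numbers for a weaker effect at the one concentration tested), compound 1 gives 5.8%. In this assay compound 2 gives 25.6%. Compound 3 returns < 1%, which is a limit of the assay and not a number, so the standing of compound 3 is known only as the limit of < 1% in this assay, at which 1 of the 3 values shown sits. Replacing the oct-1-yn-1-yl arm by bromo moves the read-out a number 19.8 percentage points higher from compound 1 to compound 2 (beyond the scatter), and putting hex-1-yn-1-yl in place of bromo moves it a number at least 24.6 percentage points lower from compound 2 to compound 3 (beyond the scatter). Shortening the chain alone gives a number at least 4.8 percentage points lower from compound 1 to compound 3 (that floor lies within the scatter), a change whose floor does not clear the scatter. Compound 4 `CC(=O)Nc1nc(-c2cccc(NS(=O)(=O)c3ccc(C#CC4CCCCC4)cc3)c2)cs1` is not yet measured; it differs from compound 3 by cyclohexyl in place of butyl on a triple-bonded carbon, the same difference cut one bond further out reading hex-1-yn-1-yl to 2-cyclohexylethynyl. Both alkyne-bearing compounds, compound 1 and compound 3, lie at or near the floor of this assay, and the two chain lengths are not separated beyond the scatter, so compound 4 is expected to stay low as well. The expected step is a number at least 2 percentage points higher from compound 3 to compound 4 (that floor lies within the scatter), within the scatter. Compound 4 is estimated at 3%, between 0% and 12%.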

Compound 4, a percentage reported as activity, at one concentration (the size of the read-out at that concentration, not a potency): 1.2%
Compound 4: the middle estimate sits 1.8 percentage points above what was measured; the range from low to high includes it.
By their numbers in this assay, from the lowest: compounds 4 and 1 (each within the scatter of the next); then compound 2. At a limit, below all of these: compound 3.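

The cyclohexyl ring on the triple-bonded carbon shows that, among the alkyne arms here, an open chain is not required for a low read-out in this assay: cyclohexyl in place of butyl gives a number at least 0.2 percentage points higher from compound 3 to compound 4 (that floor lies within the scatter). Set against the hexyl on the same carbon, cyclohexyl gives a number 4.6 percentage points lower from compound 1 to compound 4 (within the scatter), so this read-out does not separate the ring from that open chain. Against bromo on the aromatic carbon, 2-cyclohexylethynyl gives a number 24.4 percentage points lower from compound 2 to compound 4 (beyond the scatter), which extends the separation from bromo already seen with the open-chain arms of compound 1 and compound 3 to an arm that carries a ring.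

On these data alone, the true distance to compound 3 stays open, since compound 3 is known only as a limit of the assay and not as a number: the limit of < 1% in this assay, at which 1 of the 4 values shown sits. Also open are whether an amine or a carboxylic acid on the cyclohexyl ring, or a phenyl ring in its place, would keep the read-out this low, and how these compounds would separate at concentrations under the single one tested.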